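The source may report more compounds than this note shows. Statements on the series, on what has been measured and on what is new or still open speak of the compounds shown alone.

Among the measured compounds shown here, in a functional assay on MCF7 cells (Homo sapiens) for cytotoxicity, read by MTT assay, with a stated time of 96 h (on this read-out higher numbers stand for weaker inhibition and lower numbers for stronger inhibition), compound 2 `COc1ccc(-c2cn(-c3ccccc3)cc2C(=O)c2cc(OC)c(OC)c(OC)c2)cc1` gives 70 nM, the lower of the two numbers so far, while compound 1 `COc1cc(C(=O)c2cn(-c3ccccc3)cc2-c2cccc(Cl)c2)cc(OC)c1OC` gives 540 nM. Compound 3 `COc1ccc(Br)cc1-c1cn(-c2ccccc2)cc1C(=O)c1cc(OC)c(OC)c(OC)c1` has 5-bromo-2-methoxyphenyl in place of 4-methoxyphenyl on an aromatic carbon. For the measured compounds named here, only one measured step bears on this place: a 7.7-fold lower number from compound 1 to compound 2 (0.89 log units; beyond the scatter), where 4-methoxyphenyl replaced 3-chlorophenyl. The new group keeps a methoxy but gains a bromine, and the chlorine-bearing compound 1 sits at 540 nM, so a moderately higher number is expected. The expected step is a 3.1-fold higher number from compound 2 to compound 3 (0.50 log units; beyond the scatter). For compound 3 the estimate is 220 nM, with a range of 50 nM to 1000 nM.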

Compound 3, half-maximal inhibitory concentration: 2200 nM
For compound 3 the middle estimate is 10-fold (1.00 log units) below the measured one, outside the stated range (above it).
By their numbers in this assay, from the lowest: compound 2; then compound 1; then compound 3.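

In this assay, this carbon of the five-membered ring distinguishes sharply between aromatic groups: 5-bromo-2-methoxyphenyl gives a 31-fold higher number from compound 2 to compound 3 (1.50 log units; beyond the scatter), and it also gives a 4.1-fold higher number from compound 1 to compound 3 (0.61 log units; beyond the scatter). A methoxy on the incoming ring therefore does not by itself keep the low number of compound 2. Nothing measured here explains the rise. Still open, on these data alone, is whether the bromine or the moved methoxy drives the change, since a 2-methoxyphenyl without bromine would separate the two. As far as these compounds go, how a phenyl group carrying an amine would read at this carbon also remains open.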